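The source may report more compounds than this note shows. Statements on the series, on what has been measured and on what is new or still open speak of the compounds shown alone.

Working notes on the series, which shares the core of compound 1 `COc1cc(OC)c(OC)cc1/C=C/C(=O)c1ccc(OC)c2c1OC(C)(C)C=C2`. In a functional assay on HCT-116 cells (Homo sapiens) for antiproliferative activity, read by MTT assay, with a stated time of 24 h (a higher number here means a weaker inhibitor, a lower number a stronger inhibitor), compound 1 gives only a limit, > 10000 nM. Compound 2 `COc1ccc(C(=O)/C=C/c2ccc(N(C)C)cc2)c2c1C=CC(C)(C)O2` gives 1920 nM in this assay, the lowest of the two numbers in hand. Going by the values given here, compound 3 `COc1ccc(C(=O)/C=C/c2ccc(N3CCCC3)cc2)c2c1C=CC(C)(C)O2` gives 8590 nM in this assay, and the step of a 4.5-fold higher number from compound 2 to compound 3 (0.65 log units; beyond the scatter) is the only measured change at that aromatic carbon. Compound 4 `COc1ccc(C(=O)/C=C/c2ccc(Cl)cc2)c2c1C=CC(C)(C)O2` has not yet been measured; against compound 2 its change is chloro in place of dimethylamino on an aromatic carbon. Among the compounds with values here, no measured step replaces dimethylamino with chloro, so the expectation leans on compound 2 and the one step at this carbon, a 4.5-fold higher number from compound 2 to compound 3 (0.65 log units; beyond the scatter), which already raises the number on going to pyrrolidin-1-yl. Compound 4 is therefore expected to give about 6000 nM in this assay, within 2000 nM to 20000 nM. This amounts to an expected 3.1-fold higher number from compound 2 to compound 4 (0.49 log units; beyond the scatter).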

Compound 4, half-maximal inhibitory concentration: > 10000 nM
Compound 4: a limit, no number; the forecaster's own chance of this, stated with the estimate: 35%; middle value at least 1.6-fold (0.22 log units) from the limit.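

Chloro at this aromatic carbon gives an at least 5.2-fold higher number from compound 2 to compound 4 (0.71 log units; beyond the scatter), a second replacement of dimethylamino that raises the number, this time with no nitrogen in the entering group. Against pyrrolidin-1-yl, the step reads an at least 1.1-fold higher number from compound 3 to compound 4 (0.06 log units; that floor lies within the scatter), so these two cannot be ordered. The result for compound 4 is a limit, not a number: the limit of > 10000 nM in this assay, at which 2 of the 4 values shown sit.

Among the groups shown at this carbon, only dimethylamino and pyrrolidin-1-yl give numbers, so it remains open whether the nitrogen alone or the dimethylamino group as a whole sets the lower value. A primary amine, diethylamino or morpholin-4-yl at this carbon would separate these readings.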